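Methoxymethyl to ethyl at the shared core: compound 3 to 4

A few compounds are considered here, and "the series" means these few. Any claim that something is new, unique, unknown or untested is made for them only; others in the source may bear on it.

Three compounds have numbers in an assay for binding affinity to Corticotropin releasing factor receptor (Rattus norvegicus); on this read-out higher numbers stand for weaker inhibition and lower numbers for stronger inhibition. Compound 1 `CCCC(C)n1c(CC)nc2c(-c3ccc(OC)cc3C)ccnc21` gives 0.8 nM in this assay, and compound 2 `CCCC(C)n1c(CC)nc2c(-c3ccc(/C(C)=N\OC)cc3Cl)ccnc21` gives 2.3 nM. Compound 3 `CCC(CCOC)n1c(COC)nc2c(-c3ccc(C(F)(F)F)cc3Cl)ccnc21` gives 82.7 nM, the highest of the three numbers; its gaps to compound 2 and to compound 1 both lie beyond the scatter, so compound 3 is the weakest binder of the set.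

Compound 4 `CCc1nc2c(-c3ccc(C(F)(F)F)cc3Cl)ccnc2n1C(CC)CCOC` has not been measured. It differs from compound 3 in one place: methyl in place of methoxy on a saturated chain carbon bound to an aromatic carbon. Cut one bond further out, the same difference reads methoxymethyl to ethyl, so compound 4 carries the ethyl found in compound 1 and compound 2 at that spot, though both of those also differ from compound 3 in the chain on the ring nitrogen and in the aryl substituents, so their values cannot be read as a step for this change alone.

Among the measured compounds shown here, no measured pair isolates this change. The expectation is a move toward lower numbers in this assay, likely beyond the scatter but smaller than the gap between compound 3 and compound 2. Compound 4 is estimated at 30 nM, with a range from 8 nM to 100 nM, an expected step of a 2.8-fold lower number from compound 3 to compound 4 (0.44 log units; beyond the scatter).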

Compound 4, inhibition constant: 0.7 nM
Compound 4: the middle estimate sits 43-fold (1.63 log units) above what was measured; the whole stated range lies above it.
By their numbers in this assay, from the lowest: compounds 4 and 1 (each within the scatter of the next); then compound 2; then compound 3.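

Among the compounds shown here, with the aryl substituents and the chain on the ring nitrogen held constant, methyl in place of methoxy on a saturated chain carbon bound to an aromatic carbon gives a 120-fold lower number from compound 3 to compound 4 (2.07 log units; beyond the scatter) in this assay, the first reading of this change on its own. This position is therefore highly sensitive in this assay: a single change of methoxymethyl to ethyl, with one oxygen and one hydrogen-bond acceptor leaving, separates a weak binder from a strong one within this pair. No supporting measurement bears on what lies behind the size of this step.

For the compounds shown here, only this one pair carries the change, so whether a step of this size holds with other aryl substituents or another chain on the ring nitrogen remains open. Also open, on these data alone, is how a longer chain such as propyl, a hydroxymethyl or an aminomethyl at this position would read in this assay compared with the ethyl of compound 4.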